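Butyl to tert-butyl on the aryl ring of compound 3

A few compounds are considered here, and "the series" means these few. Any claim that something is new, unique, unknown or untested is made for them only; others in the source may bear on it.

Compound 1 `O=C1C2=C(C(=O)c3ncccc31)C1(CS2)NC(=O)N(c2ccc([N+](=O)[O-])cc2)C1=O` gives 250 nM in a functional assay on HT-29 cells (Homo sapiens) for antiproliferative activity, read by MTT assay, with a stated time of 96 h; a lower number here means a stronger inhibitor, a higher number a weaker inhibitor.
Compound 2 `O=C1C2=C(C(=O)c3ncccc31)C1(CS2)NC(=O)N(c2ccccc2)C1=O` gives 2 nM in this assay.
Compound 3 `CCCCc1ccc(N2C(=O)NC3(CSC4=C3C(=O)c3ncccc3C4=O)C2=O)cc1` gives 50 nM in this assay.

Compound 3 holds the second highest of the three numbers: a 5.0-fold lower number from compound 1 to compound 3 (0.70 log units; beyond the scatter), while a 25-fold higher number from compound 2 to compound 3 (1.40 log units; beyond the scatter). Compound 4 `CC(C)(C)c1ccc(N2C(=O)NC3(CSC4=C3C(=O)c3ncccc3C4=O)C2=O)cc1` differs from compound 3 by tert-butyl in place of butyl on an aromatic carbon. For the measured compounds named here, no measured step exchanges one four-carbon group for another; the only step touching this carbon is a 25-fold higher number from compound 2 to compound 3 (1.40 log units; beyond the scatter), which shows that a group here matters, but not how its branching does. With the same atoms joined differently, the expected step of no change at the digits printed from compound 3 to compound 4 (within the scatter) in this assay is none beyond the scatter. Compound 4 is therefore estimated at 50 nM in this assay, within 15 nM to 160 nM.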

Compound 4, half-maximal inhibitory concentration: 150 nM
Beside the measured number, compound 4's estimate is 3.0-fold (0.48 log units) below it; the range from low to high includes it.
By their numbers in this assay, from the lowest: compound 2; then compound 3; then compounds 4 and 1 (each within the scatter of the next).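

In this assay branching alone moves this position: a 3.0-fold higher number from compound 3 to compound 4 (0.48 log units; beyond the scatter) with the same atoms joined differently, so how the four carbons are joined counts and not only their number. Hydrogen still stands clear of the branched group, with a 75-fold higher number from compound 2 to compound 4 (1.88 log units; beyond the scatter) on that exchange, whereas a 1.7-fold lower number from compound 1 to compound 4 (0.22 log units; within the scatter) leaves tert-butyl and nitro unresolved from each other. Nothing measured on these compounds explains the cost of branching.

Open, as far as these compounds go, is whether a shorter chain such as methyl or ethyl keeps activity nearer to compound 2. An amine or a methoxy group at this carbon also remains to be placed in the series.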